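This account rests on a few compounds, and the source may have more. Where it says the series, first, only, none or still open, it means among the compounds named here.

Of the compounds shown here, two have so far been measured in a functional assay on HEK293 cells for activation of 5-hydroxytryptamine receptor 4 (Homo sapiens), read by cAMP accumulation; a lower number here means a smaller maximal response, a higher number a larger maximal response. Compound 1, `CC(C)n1c(=O)n(C(=O)NCC2CCNCC2)c2ccccc21`, gives 92% in this assay. Compound 2, `CCCCCN1CCC(NC(=O)c2cc(Cl)c(N)cc2OC)CC1`, reaches a limit of this assay rather than a number, reported as > 100%. Compound 2 thus stands at the limit of > 100% in this assay, at which 1 of the 2 values shown sits. Compound 3, `COc1cc(N)c(Cl)cc1C(=O)NC1CCN(CCCCCCCCN2CCCCC2)CC1`, has not yet been measured in this assay. It differs from compound 2 by 3-(piperidin-1-yl)propyl in place of hydrogen on a saturated chain carbon, five bonds along the chain from an amine nitrogen in a ring. Among the compounds with values here, no step between two measured compounds is available, so the expected step from compound 2 to compound 3 in this assay can only be judged from the change itself. With compound 2 at > 100%, a large maximal response remains the starting point for the expectation. A modest step downward, possibly within the usual scatter, is expected for a number at least 10 percentage points lower from compound 2 to compound 3 (that floor lies within the scatter). Compound 3 is therefore estimated at 90%, within a range from 60% to 110%.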

Compound 3, intrinsic activity: the largest response reached, in percent of the reference agonist's: > 100%
Compound 3 gave a limit, no number; the forecaster's own chance of this, stated with the estimate: 25%; at least 10 percentage points between middle value and limit.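

Within the data shown here, compound 3, like compound 2, stands at a limit of this assay rather than at a number, so no step between compound 2 and compound 3 can be read: the limit of > 100% in this assay, at which 2 of the 3 values shown sit. The compounds shown leave open whether 3-(piperidin-1-yl)propyl in place of hydrogen changes the maximal response at all.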